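Notes on a half-life series: sulfone to tertiary alcohol

A few compounds are considered here, and "the series" means these few. Any claim that something is new, unique, unknown or untested is made for them only; others in the source may bear on it.

Two compounds of the series have been run so far. Compound 1 `NS(=O)(=O)CC(=O)NCCSc1nonc1/C(=N/O)Nc1cccc(Cl)c1` in an ADME assay on isolated protein for pharmacokinetics, with UDP-glucuronosyltransferase 1A9 (Homo sapiens) as the target, read by LC-MS, with a stated time of 60 min, at 37 degrees C, tested at 1 uM, in the presence of a further agent that is not named here (a higher number here means that the compound lasts longer, a lower number that the compound disappears faster), gives 0.9 h. Compound 2 `CS(=O)(=O)CC(=O)NCCSc1nonc1/C(=N/O)Nc1ccc(F)c(C(F)F)c1`, which carries a methylsulfonyl on the chain and a different aryl group, gives in this assay a half-life of 1.59 h. On these two numbers compound 2 and compound 1 sit within the scatter of each other, so neither stands apart and no direction can be read from the pair. For the measured compounds named here, there is no matched pair differing in a single place, so no measured step is available to lean on.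

Compound 3 `CC(C)(O)CC(=O)NCCSc1nonc1/C(=N/O)Nc1ccc(F)c(C(F)F)c1` keeps the aryl group and chain of compound 2; the difference is 1-hydroxy-1-methylethyl in place of methylsulfonyl on a saturated chain carbon bound to a carbonyl carbon.

With nothing measured on this kind of change, the expectation is that the step from compound 2 to compound 3 stays within the scatter or drifts slightly downward, a 1.3-fold lower number from compound 2 to compound 3 (0.12 log units; within the scatter) in this assay. Compound 3 is therefore estimated at 1.2 h, with a range from 0.5 h to 2.6 h.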

Compound 3, half-life: > 3 h
Compound 3: a limit, no number; the forecaster's own chance of this, stated with the estimate: 5%; middle value at least 2.5-fold (0.39 log units) from the limit.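

For the compounds shown here, replacing methylsulfonyl with 1-hydroxy-1-methylethyl on a saturated chain carbon bound to a carbonyl carbon gives the only single-place step so far, an at least 1.8-fold higher number from compound 2 to compound 3 (0.27 log units; that floor lies within the scatter), in this assay. Compound 3 gives > 3 h, which is a limit of the assay and not a number. This position therefore accepts the change without any visible drop in half-life, but the step is a floor and not a size, and that floor alone does not set compound 3 apart from compound 2, with the reading resting on this limit: the limit of > 3 h in this assay, at which 1 of the 3 values shown sits.

From the compounds shown here alone, the true half-life of compound 3 remains open, as does whether the step from methylsulfonyl to 1-hydroxy-1-methylethyl would carry over to the aryl group of compound 1. Also open, going by these compounds, is how an amine, a carboxylic acid or a longer chain on the same saturated chain carbon would compare with 1-hydroxy-1-methylethyl on the aryl group shared by compound 2 and compound 3.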